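The source may report more compounds than this note shows. Statements on the series, on what has been measured and on what is new or still open speak of the compounds shown alone.

Series notes. Compound 1 `CC(C(=O)N1CCN(c2ccccc2)CC1)N1C(=O)CCC1=O` gives 50% in a functional assay on the whole organism (strain Swiss) with Mus musculus as the target, in the maximal electroshock model, with a stated time of 0.25 h, at a dose of 100 mg/kg by the intraperitoneal route; a higher number here means a stronger effect of the compound at the dose given, a lower number a weaker effect. Compound 2 `CCC(C(=O)N1CCN(c2cccc(C)c2)CC1)N1C(=O)CCC1=O` gives 50% in the same assay, and compound 3 `CCC(C(=O)N1CCN(c2cccc(Cl)c2)CC1)N1C(=O)CCC1=O` gives 50%. Compound 3 thus stands level with compounds 1 and 2 at the digits reported; the gap to each lies within the scatter, so no order among the three is claimed.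

The step from compound 3 to compound 4 `CCC(C(=O)N1CCN(c2ccccc2)CC1)N1C(=O)CCC1=O` is hydrogen in place of chloro on an aromatic carbon, on an aromatic carbon of a six-membered aromatic ring of carbon only. Among the measured compounds shown here, the one measured step that bears on this position is the exchange at the same carbon, which gave no change at the digits printed from compound 2 to compound 3 (within the scatter); a change at this place between two groups left the read-out untouched. For the measured compounds named here, no measured pair shows the bare ring against a substituted ring with an otherwise identical chain, but compound 1, which carries the unsubstituted ring, sits at the same level as compounds 2 and 3.

On this basis the expected step in this assay is no change at the digits printed from compound 3 to compound 4 (within the scatter), that is, nothing beyond the scatter. Compound 4 is therefore estimated at 50%, with a range from 30% to 70%.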

Compound 4, a percentage reported as activity, at one dose (the size of the read-out at that dose, not a potency): 25%
Beside the measured number, compound 4's estimate is 25 percentage points above it; the whole stated range lies above it.
By their numbers in this assay, from the lowest: compound 4; then compounds 1, 2 and 3 (each within the scatter of the next).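

In this assay the ring position now proves to matter on this chain: hydrogen in place of chloro gives a number 25 percentage points lower from compound 3 to compound 4 (beyond the scatter), and hydrogen in place of methyl gives a number 25 percentage points lower from compound 2 to compound 4 (beyond the scatter), so the level held by chloro and methyl alike is not held by the bare ring. The bare ring is not low in itself, as compound 1 also carries it; methyl in place of hydrogen on the saturated chain carbon gives a number 25 percentage points lower from compound 1 to compound 4 (beyond the scatter), so the effect of the chain carbon depends on the ring, or the effect of the ring substituent depends on the chain, among these four compounds. Nothing available gives a reason for either step.

From the compounds shown here alone, how a chloro or methyl group on the ring would read out on the shorter chain of compound 1 remains open, so the two places cannot yet be separated as independent or linked. Also open, going by these compounds, is whether a methoxy group, a trifluoromethyl group or an amine at the same ring carbon would hold the level of compound 3, and whether a longer chain on the saturated carbon would lower the read-out further.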